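The source may report more compounds than this note shows. Statements on the series, on what has been measured and on what is new or still open speak of the compounds shown alone.

Measured compounds:
compound 1 `CCCC#Cc1cn([C@@H]2O[C@H](CO)[C@@H](O)[C@H](O)[C@H]2O)c(=O)nc1N` in a functional assay on CCRF-CEM cells (Homo sapiens) for cytotoxicity, with a stated time of 72 h; on this read-out higher numbers stand for weaker inhibition and lower numbers for stronger inhibition > 250000 nM
compound 2 `O=c1nc(O)c(C#Cc2ccccc2)cn1[C@@H]1O[C@H](CO)[C@@H](O)[C@H](O)[C@H]1O` 5200 nM

Compound 1 reaches only a limit of the assay; its value is not a number. Among the measured compounds shown here, compound 2 gives the only number in the set, and no step between two measured compounds can be drawn, since compound 1 and compound 2 differ in two places at once. Where compound 2 stands is therefore fixed by a single value, with compound 1 sitting at the limit of > 250000 nM in this assay, at which 1 of the 2 values shown sits.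

Compound 3 `Nc1nc(=O)n([C@@H]2O[C@H](CO)[C@@H](O)[C@H](O)[C@H]2O)cc1C#Cc1ccccc1` is not yet measured. It keeps the 2-phenylethynyl group of compound 2 and changes only the substituent on the shared core: amino in place of hydroxy on an aromatic carbon. For the measured compounds named here, no measured step tells what this change alone does; the only amino-bearing compound, compound 1, carries a different alkyne and sits at the limit. The expectation for compound 3 is a step of a 2.3-fold higher number from compound 2 to compound 3 (0.36 log units; beyond the scatter), in the direction of weaker inhibition, a modest change whose size is uncertain. Compound 3 is estimated at 12000 nM, within 3000 nM to 60000 nM.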

Compound 3, half-maximal inhibitory concentration: > 250000 nM
Compound 3 gave a limit, no number; the forecaster's own chance of this, stated with the estimate: 30%; at least 20-fold (1.31 log units) between middle value and limit.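

In this assay, among the compounds shown here, the first readable step at this position is an at least 48-fold higher number from compound 2 to compound 3 (1.68 log units; beyond the scatter), for amino in place of hydroxy on an aromatic carbon, ortho to a 2-phenylethynyl group; compound 3 gives a limit of the assay and not a number, so the true size of the step stays unknown. The swap leaves the counts of heavy atoms, hydrogen-bond donors and hydrogen-bond acceptors unchanged, yet among the compounds shown only compound 2, the hydroxy compound, gives a number. With amino in place, phenyl and propyl on the triple-bonded carbon cannot be told apart, and the step between compound 1 and compound 3 cannot be read: the limit of > 250000 nM in this assay, at which 2 of the 3 values shown sit.

Open, on these data alone, is whether a methoxy or a methylamino group at this position would give a number in this assay or stay at the limit, and how far past the limit the two amino compounds lie. Also open, as far as these compounds go, is whether hydroxy with propyl on the triple-bonded carbon would give a number as well, which would show whether the step seen here holds beyond the 2-phenylethynyl group.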